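Swapping the chain terminus: from methylpiperazine to diethylamine

This account rests on a few compounds, and the source may have more. Where it says the series, first, only, none or still open, it means among the compounds named here.

Of the compounds shown here, two have been measured in an ADME assay on the whole organism (Mus musculus, strain C57BL/6) for pharmacokinetics, read by LC-MS, at a dose of 2 mg/kg by the subcutaneous route; a higher number here means more compound in the circulation at the dose given, a lower number less compound in the circulation. Compound 1 `Cc1ccccc1C(=O)Nc1ccc(C(=O)N2CCCC(NCCC(=O)N3CCOCC3)c3cc(Cl)ccc32)c(C)c1` gives 1330 nM, and compound 2 `Cc1ccccc1C(=O)Nc1ccc(C(=O)N2CCCC(NCCCN3CCN(C)CC3)c3cc(Cl)ccc32)c(C)c1` gives 881 nM. Among the compounds with values here, the only measured step, a 1.5-fold lower number from compound 1 to compound 2 (0.18 log units; within the scatter), shows that replacing the terminus of the side chain left the number within the scatter. Compound 2 therefore stands at the lower of the two numbers, although its gap to compound 1 is within the scatter. Compound 3 `CCN(CC)CCCNC1CCCN(C(=O)c2ccc(NC(=O)c3ccccc3C)cc2C)c2ccc(Cl)cc21` has not yet been measured in this assay; it differs from compound 2 by diethylamino in place of 4-methylpiperazin-1-yl on a saturated chain carbon, three bonds along the chain from an amine nitrogen. Within the data shown here, only the step from compound 1 to compound 2 bears on this change, and it was within the scatter. A step of similar size, or none beyond the scatter, is expected from compound 2 to compound 3, namely a 1.0-fold higher number from compound 2 to compound 3 (0.01 log units; within the scatter). Compound 3 is therefore estimated at 900 nM, within a range from 350 nM to 2300 nM.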

Compound 3, maximal plasma concentration in the Mus musculus assay: 759 nM
Compound 3: middle estimate off by 1.2-fold (0.07 log units), on the high side, and the stated range covers the measured number.
By their numbers in the Mus musculus assay, from the lowest: compounds 3, 2 and 1 (each within the scatter of the next).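

In the Mus musculus assay, a 1.2-fold lower number from compound 2 to compound 3 (0.06 log units; within the scatter) comes with losing the ring of 4-methylpiperazin-1-yl to the open diethylamino, and a 1.8-fold lower number from compound 1 to compound 3 (0.24 log units; within the scatter) holds when the comparison reaches back to (morpholin-4-yl)carbonyl, so three different chain ends at this position now sit within the scatter of one another. The same swap also leaves a physicochemical assay for solubility, measured as thermodynamic solubility, with a stated time of 24 h (a higher number here means a more soluble compound, a lower number a less soluble compound), flat, with no change at the digits printed from compound 2 to compound 3 (within the scatter) and with compound 2 at 2.3 ug/mL and compound 3 at 2.3 ug/mL in that read-out. Nothing shown here accounts for either result.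

Going by these compounds, whether any chain end can move the circulating level beyond the scatter stays open, for instance a carboxylic acid or a primary amine at this position. A longer chain carrying the diethylamino group is likewise untested by the compounds shown.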